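Shortening the hexyl chain on a purine core

This account rests on a few compounds, and the source may have more. Where it says the series, first, only, none or still open, it means among the compounds named here.

Compound 1 `CCCCCCn1cnc2c(Nc3ccc(O)cc3)nc(N[C@H]3CC[C@H](N)CC3)nc21` — 3500 nM
Compound 2 `CC(C)CCn1cnc2c(NCc3cccc(Cl)c3)nc(N[C@H]3CC[C@H](N)CC3)nc21` — 4700 nM
Compound 3 `CCCCCCn1cnc2c(Nc3cccc(Cl)c3)nc(N[C@H]3CC[C@H](N)CC3)nc21` — 2700 nM

In a functional assay on MCF7 cells (Homo sapiens) for inhibition, read by fluorescence, with a stated time of 72 h (on this read-out higher numbers stand for weaker inhibition of growth and lower numbers for stronger inhibition of growth), compound 3 gives the lowest of the three numbers, yet its nearest neighbour compound 1 sits only a little way off and compound 2 further, and both gaps lie within the scatter, so none of the three can be called stronger or weaker than another. Among the measured compounds shown here, the one single-place step that has been measured, a 1.3-fold lower number from compound 1 to compound 3 (0.11 log units; within the scatter), is itself within the scatter and concerns the aryl group on the amine, not the chain on the aromatic nitrogen.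

Compound 4 `CCCCn1cnc2c(Nc3cccc(Cl)c3)nc(N[C@H]3CC[C@H](N)CC3)nc21` differs from compound 3 only in that chain: hydrogen in place of ethyl on a saturated chain carbon, four bonds along the chain from an aromatic nitrogen. For the measured compounds named here, no measured pair shows what removing two chain carbons at this position does; compound 2 carries a different chain but also a different amine, so its value cannot be read as a chain effect. With nothing pointing in either direction, compound 4 is expected to stay close to compound 3, the estimated step of a 1.1-fold higher number from compound 3 to compound 4 (0.05 log units; within the scatter) lying within the scatter. Compound 4 is therefore estimated at 3000 nM, with a range from 1200 nM to 8000 nM.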

Compound 4, concentration for 50% growth inhibition: 2000 nM
Estimate against measurement, compound 4: 1.5-fold (0.18 log units) above, and the stated range covers the measured number.
By their numbers in this assay, from the lowest: compounds 4, 3, 1 and 2 (each within the scatter of the next, the first and the last beyond it).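

Among the compounds shown here, at this place, hydrogen in place of ethyl on a saturated chain carbon, four bonds along the chain from an aromatic nitrogen, gives the first reading of the chain alone: in this assay the change is a 1.4-fold lower number from compound 3 to compound 4 (0.13 log units; within the scatter), which cannot be told apart from no change. For the compounds shown here, the earlier compounds could not show this, as their only single-place step, a 1.3-fold lower number from compound 1 to compound 3 (0.11 log units; within the scatter), concerned the aryl group on the amine, and compound 2 differs from compound 3 in more than one place. No other measurement bears on this result or offers a reason for it.

Going by these compounds alone, what the compounds leave open is how far the chain can be altered before the number in this assay moves beyond the scatter, since only this one chain change can be read, and a propyl or methyl group on the aromatic nitrogen, or a chain ending in a hydroxyl or an amine, would test that further. From the compounds shown here alone, it also remains open whether the same shortening reads alike when the 3-chlorophenyl group is replaced by the 4-hydroxyphenyl group of compound 1.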